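Chloro-methyl pyridazine on the shared urea core

The compounds below may be only part of what the source reports. "The series", "measured", "known", "first", "only" and "open" are said of these compounds alone.

Compound 1 `Cc1ccc(N2CCN(C(=O)Nc3ccc(C(F)(F)F)cc3)CC2)nn1` carries a trifluoromethyl group on its aromatic ring. In an assay on HEK293 cells for inhibition of transient receptor potential cation channel subfamily V member 1 (Homo sapiens), read by FLIPR (on this read-out higher numbers stand for weaker inhibition and lower numbers for stronger inhibition), compound 1 gives only a limit of > 10000 nM. Compound 2 `Cc1ccc(N2CCN(C(=O)Nc3ccc(OC(F)(F)F)cc3)CC2)nn1` differs by a trifluoromethoxy in place of trifluoromethyl on an aromatic carbon. In this assay compound 2 likewise gives only a limit of > 10000 nM. The step that the two limits leave unreadable from compound 1 to compound 2 cannot be read, because of the limit of > 10000 nM in this assay, at which 2 of the 2 values shown sit. Among the measured compounds shown here, compound 2 thus stands at the same limit as the only other measured compound, with no number that would rank it.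

Compound 3 `Cc1cc(N2CCN(C(=O)Nc3ccc(OC(F)(F)F)cc3)CC2)nnc1Cl` is not yet measured. It differs from compound 2 by 6-chloro-5-methylpyridazin-3-yl in place of 6-methylpyridazin-3-yl on an amine nitrogen in a ring. For the measured compounds named here, no measured step touches this part of the shared core, and the one step on record, between two limits, gives no size in either direction. The expectation is therefore that compound 3 stays close to where compound 2 stands, with a step of a number no higher from compound 2 to compound 3 (the limit leaves the size open) not expected to exceed the scatter. For compound 3 the estimated value is 10000 nM, within a range from 2500 nM to 40000 nM.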

Compound 3, half-maximal inhibitory concentration: > 10000 nM
Compound 3: a limit, no number (the forecaster's own chance of this, stated with the estimate: 75%); the middle value sits exactly at the limit.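

In this assay compound 3 gives > 10000 nM, which is a limit and not a number. The step from compound 2 to compound 3 therefore cannot be read, because no compound shown gives a number: the limit of > 10000 nM in this assay, at which 3 of the 3 values shown sit. The compounds shown leave open how large either change on the shared core is, and in which direction it acts.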